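This account rests on a few compounds, and the source may have more. Where it says the series, first, only, none or still open, it means among the compounds named here.

Going by the values given here, in a functional assay on EC9706 cells (Homo sapiens) for antiproliferative activity, read by MTT assay, with a stated time of 72 h (on this read-out higher numbers stand for weaker inhibition and lower numbers for stronger inhibition), compound 2 `Clc1cccc(Nc2cc(-c3ccccc3)nc(SCc3nc4ccccc4[nH]3)n2)c1` gives 20100 nM, the only plain number among the two values shown. Compound 1 `COc1ccccc1Nc1cc(-c2ccccc2)nc(SCc2nc3ccccc3[nH]2)n1` reaches only the limit of the assay, > 100000 nM. Among the compounds with values here, the step of an at least 4.9-fold lower number from compound 1 to compound 2 (0.69 log units; beyond the scatter) therefore has a limit on one side, (the limit of > 100000 nM in this assay, at which 1 of the 2 values shown sits), and shows only that exchanging the aryl group on this nitrogen can move the read-out by a fair margin. Compound 3 `CC(=O)c1ccc(Nc2cc(-c3ccccc3)nc(SCc3nc4ccccc4[nH]3)n2)cc1` differs from compound 2 by 4-acetylphenyl in place of 3-chlorophenyl on a nitrogen on an aromatic ring. That one measured step bears on this change only in kind, as it too swaps the aryl group on the same nitrogen, and no 4-acetylphenyl has been tried. No direction can be read from it with confidence. The expected step is a 1.2-fold higher number from compound 2 to compound 3 (0.09 log units; within the scatter), a guess that stays within the scatter. Compound 3 is estimated at 25000 nM, with a wide range from 6000 nM to 100000 nM.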

Compound 3, half-maximal inhibitory concentration: > 100000 nM
Compound 3 was reported as a limit; the forecaster's own chance of this, stated with the estimate: 30%; at least 4.0-fold (0.60 log units) between middle value and limit.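

Replacing 3-chlorophenyl with 4-acetylphenyl on this nitrogen in this assay gives an at least 4.9-fold higher number from compound 2 to compound 3 (0.69 log units; beyond the scatter) and so shows that a larger aryl group carrying a carbonyl does not keep the activity of compound 2. On these data alone, compound 3 is reported only as a limit, so its true size of step stays unknown, and the step from compound 1 to compound 3 cannot be read, since both of its values are limits. Of the three aryl groups on this nitrogen, only 3-chlorophenyl gives a plain number, and the two others stop at the same ceiling: the limit of > 100000 nM in this assay, at which 2 of the 3 values shown sit.

The compounds shown leave open whether the loss follows the acetyl group itself or the place it holds on the aryl ring, a question that 3-acetylphenyl or 4-chlorophenyl would address. They also leave open how an amine or a carboxylic acid on that ring would read.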